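Trimming a Methyl from the Amide Aryl Ring

The compounds below may be only part of what the source reports. "The series", "measured", "known", "first", "only" and "open" are said of these compounds alone.

In a functional assay on CHO cells for antagonist activity at Orexin receptor type 2 (Homo sapiens), read by FLIPR and calcium flux (on this read-out lower numbers stand for stronger inhibition and higher numbers for weaker inhibition), compound 2 `COc1ccc(C)cc1NC(=O)CSc1nnc(-c2ccoc2C)n1Cc1ccco1` gives 15.9 nM, the lowest of the two numbers in view. Compound 3 `Cc1occc1-c1nnc(SCC(=O)Nc2ccc(Cl)cc2)n1Cc1ccco1` gives 100 nM in this assay. Compound 1 `Cc1cccc(C)c1NC(=O)CSc1nnc(-c2ccoc2C)n1Cc1ccco1` reaches only the limit > 15800 nM in this assay. Compound 4 `COc1ccccc1NC(=O)CSc1nnc(-c2ccoc2C)n1Cc1ccco1` differs from compound 2 by hydrogen in place of methyl on an aromatic carbon. Among the compounds with values here, no measured step removes this methyl alone; the nearest comparison is a 6.3-fold higher number from compound 2 to compound 3 (0.80 log units; beyond the scatter), a modest loss when the whole ring pattern changes, while an at least 990-fold lower number from compound 1 to compound 2 (2.99 log units; beyond the scatter) and an at least 150-fold lower number from compound 1 to compound 3 (2.19 log units; beyond the scatter) are large but start from a limit. A modest step in this assay is therefore expected, toward a higher number. Compound 4 is estimated at 40 nM, between 12 nM and 130 nM, which would mean a 2.5-fold higher number from compound 2 to compound 4 (0.40 log units; beyond the scatter).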

Compound 4, inhibition constant: 501 nM
Compound 4: the middle estimate sits 13-fold (1.10 log units) below what was measured, and the stated range ends below it.
By their numbers in this assay, from the lowest: compound 2; then compound 3; then compound 4. At a limit, above all of these: compound 1.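

Removing only the methyl para to a methoxy group has a large effect in this assay, giving a 32-fold higher number from compound 2 to compound 4 (1.50 log units; beyond the scatter). The 2-methoxyphenyl ring without that methyl also falls behind the 4-chlorophenyl ring, giving a 5.0-fold higher number from compound 3 to compound 4 (0.70 log units; beyond the scatter), so the methoxy group alone does not preserve the advantage seen with compound 2. Compound 1 has a limit rather than a true number, so its step is open-ended: an at least 31-fold lower number from compound 1 to compound 4 (1.49 log units; beyond the scatter).

On these data alone, whether an ethyl group, a fluorine atom or a chlorine atom could replace this methyl remains open. So does whether the methyl would matter without the methoxy group.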